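The source may report more compounds than this note shows. Statements on the series, on what has been measured and on what is new or still open speak of the compounds shown alone.

Working notes on the series. In a functional assay on HepG2 cells (Homo sapiens) for inhibition, read by MTT assay, with a stated time of 24 h (on this read-out lower numbers stand for stronger inhibition and higher numbers for weaker inhibition), compound 1 `CC1(C)[C@H]2CC[C@]1(C)N(Cc1cn(-c3ccccc3F)nn1)C(=O)C2` gives 60 nM and compound 2 `CC1(C)[C@H]2CC[C@]1(C)N(Cc1cn(-c3ccccc3Cl)nn1)C(=O)C2` gives 60 nM, while compound 3 `CC1(C)[C@H]2CC[C@]1(C)N(Cc1cn(-c3cccc(Cl)c3)nn1)C(=O)C2` gives 60 nM as well, so compound 3 stands level with both. The next entry is compound 4 `CC1(C)[C@H]2CC[C@]1(C)N(Cc1cn(-c3ccc(Br)cc3)nn1)C(=O)C2`. Going by the values given here, its one structural difference from compound 3 is 4-bromophenyl in place of 3-chlorophenyl on an aromatic nitrogen with 4-bromophenyl in place of 3-chlorophenyl on an aromatic nitrogen of a five-membered aromatic ring with 3 nitrogen. Three measured steps on this same aromatic group bear on it. The step of no change at the digits printed from compound 1 to compound 2 (within the scatter) exchanges one halogen for another, the step of no change at the digits printed from compound 2 to compound 3 (within the scatter) relocates the chloro, and the step of no change at the digits printed from compound 1 to compound 3 (within the scatter) does both. All three stay within the scatter. Among the compounds with values here, no measured compound carries 4-bromophenyl, so the read-across is indirect, and no step beyond the scatter is expected in this assay in either direction. The estimated step of no change at the digits printed from compound 3 to compound 4 (within the scatter) is expected to reflect that flat picture. For compound 4 an estimated 60 nM is expected, with a range of 27 nM to 130 nM around it.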

Compound 4, half-maximal inhibitory concentration: 110 nM
Estimate against measurement, compound 4: 1.8-fold (0.26 log units) below; the range from low to high includes it.
By their numbers in this assay, from the lowest: compounds 1, 2, 3 and 4 (each within the scatter of the next).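

In this assay a bromine-bearing phenyl on the aromatic nitrogen stays within the scatter of all three earlier compounds (a 1.8-fold higher number from compound 3 to compound 4 (0.26 log units; within the scatter) and a 1.8-fold higher number from compound 2 to compound 4 (0.26 log units; within the scatter) and a 1.8-fold higher number from compound 1 to compound 4 (0.26 log units; within the scatter)). The flat picture at this place therefore now spans 2-fluorophenyl, 2-chlorophenyl, 3-chlorophenyl and 4-bromophenyl, so neither the halogen nor its place on the phenyl separates these four compounds in this assay. No measurement at hand gives a reason for these steps.

Each step to compound 4 exchanges the halogen and relocates it at once, so the two changes cannot be read apart. As far as these compounds go, whether a phenyl carrying an amine or a carboxylic acid, or a longer chain at this place, would give a step beyond the scatter stays open.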